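Replacing the Amino Group with a Pyrrolidine Amide

The source may report more compounds than this note shows. Statements on the series, on what has been measured and on what is new or still open speak of the compounds shown alone.

Measured compounds:
compound 1, `CN1CCC[C@H]1COc1cncc(Cl)c1`, 0.6 nM
compound 2, `CN1CCC[C@H]1COc1cncc(N)c1`, 0.63 nM

In an assay on membranes from brain for displacement of a labelled ligand from Neuronal acetylcholine receptor; alpha4/beta2 (Rattus norvegicus) (a higher number here means a weaker inhibitor, a lower number a stronger inhibitor), compound 1 gives 0.6 nM and compound 2 gives 0.63 nM. Among the measured compounds shown here, the one measured step, a 1.1-fold higher number from compound 1 to compound 2 (0.02 log units; within the scatter), shows that swapping chloro for amino changed nothing beyond the scatter, so compound 2 sits alongside compound 1 in this assay. Compound 3, `CN1CCC[C@H]1COc1cncc(C(=O)N2CCCC2)c1`, differs from compound 2 in that ((pyrrolidin-1-yl)carbonyl in place of amino on an aromatic carbon). This change is much larger than the measured one, so that step gives little guidance. A bigger group at this place is expected to weaken binding, with the step of a 48-fold higher number from compound 2 to compound 3 (1.68 log units; beyond the scatter). Compound 3 is therefore estimated at 30 nM, between 3 nM and 300 nM.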

Compound 3, inhibition constant: 19.9 nM
Compound 3: middle estimate off by 1.5-fold (0.18 log units), on the high side; the range from low to high includes it.
By their numbers in this assay, from the lowest: compounds 1 and 2 (each within the scatter of the next); then compound 3.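

Chloro and amino read alike at this position, but (pyrrolidin-1-yl)carbonyl brings a 32-fold higher number from compound 2 to compound 3 (1.50 log units; beyond the scatter) and a 33-fold higher number from compound 1 to compound 3 (1.52 log units; beyond the scatter) in the same direction, so this place does not accept every group equally. This swap brings in seven heavy atoms where amino has one, and the ring and the carbonyl enter together. On these data alone, whether the weaker binding follows the ring or the carbonyl stays open, and a methyl amide or a carboxylic acid at this place could help separate the two. No measurement at hand offers an explanation for the weaker binding.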